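Cytotoxicity on Vero cells: tolerance kept at the limit

The compounds below may be only part of what the source reports. "The series", "measured", "known", "first", "only" and "open" are said of these compounds alone.

Compound 3 (`COC(=O)c1cc(-c2cccc(NC(=O)c3ccc(/C=C/C(=O)c4ccc(Br)cc4)cc3)c2)on1`) has only a limit in an ADME assay on Vero cells (Chlorocebus sabaeus) for cytotoxicity, read by MTT assay, with a stated time of 72 h (a lower number here means that less compound is tolerated, a higher number that more compound is tolerated), namely > 20 ug/mL. Compound 1 (`COC(=O)c1cc(-c2cccc(NC(=O)c3ccc(/C=C/C(=O)c4ccccc4Br)cc3)c2)on1`) also gives a limit in this assay, > 40 ug/mL. Compound 2 (`CCOc1ccc(C(=O)/C=C/c2ccc(C(=O)Nc3cccc(-c4cc(C(=O)OC)no4)c3)cc2)cc1`) likewise stops at a limit, > 40 ug/mL. Because of this, a step that the two limits leave unreadable from compound 1 to compound 3, a step that the two limits leave unreadable from compound 2 to compound 3 and a step that the two limits leave unreadable from compound 1 to compound 2 cannot be sized; the limit of > 40 ug/mL in this assay, at which 2 of the 3 values shown sit, and the limit of > 20 ug/mL in this assay, at which 1 of the 3 values shown sits, are all that these three values show. Compound 4 (`COC(=O)c1cc(-c2cccc(NC(=O)c3ccc(/C=C/C(=O)c4ccccc4C)cc3)c2)on1`) differs from compound 3 by 2-methylphenyl in place of 4-bromophenyl on a carbonyl carbon. With no readable step to guide it, the expectation is that the change from compound 3 to compound 4 stays within scatter, a step that the limit leaves unreadable from compound 3 to compound 4. Compound 4 is therefore estimated at 50 ug/mL in this assay, within 25 ug/mL to 100 ug/mL, most likely again as a limit.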

Compound 4, half-maximal cytotoxic concentration: > 25 ug/mL
Compound 4: no number, only a limit (the forecaster's own chance of this, stated with the estimate: 80%); the middle value does not contradict the limit.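

Compound 4 also stops at a limit in this assay, and its steps from compound 1, compound 2 and compound 3 cannot be read. The compounds shown leave open at what concentration any of the four harms these cells, and whether changing the group on the carbonyl carbon shifts it.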